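This account rests on a few compounds, and the source may have more. Where it says the series, first, only, none or still open, it means among the compounds named here.

Measured in a functional assay on KB cells (Homo sapiens) for inhibition; a higher number here means a weaker inhibitor, a lower number a stronger inhibitor:
Compound 1 `OCC(CO)OCn1c(Cl)nc2cc(Cl)c(Cl)cc21`: > 100000 nM
Compound 2 `Nc1nc2c(Cl)c(Cl)ccc2n1COC(CO)CO`: > 100000 nM

Compound 2 gives > 100000 nM, which is a limit of the assay and not a number. Compound 1 stands in the same place, as the limit of > 100000 nM in this assay, at which 2 of the 2 values shown sit, shows.

Compound 3 `CN(C)c1nc2c(Cl)c(Cl)ccc2n1COC(CO)CO` has dimethylamino in place of amino on an aromatic carbon. Among the measured compounds shown here, no measured pair shows what this change does. For the measured compounds named here, the only guide is compound 2, with its limit of > 100000 nM, so no step beyond the scatter is expected in this assay. The expected change is a number no higher from compound 2 to compound 3 (the limit leaves the size open). For compound 3 the estimated value is 100000 nM, within an expected range of 30000 nM to 200000 nM.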

Compound 3, half-maximal inhibitory concentration: > 100000 nM
Compound 3 gave a limit, no number (the forecaster's own chance of this, stated with the estimate: 75%); the middle value sits exactly at the limit.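

Compound 2 and compound 3 both sit at a limit and not at a number, so no step can be read between them: the limit of > 100000 nM in this assay, at which 3 of the 3 values shown sit.

As far as these compounds go, what dimethylamino in place of amino does to inhibition stays open, as does the true strength of all three compounds.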